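The source may hold more compounds than are shown below. What is called first, only, known or untested is meant among the compounds shown, and "the series" means these compounds.

Compound 1 `O=C(Nc1ccc(S(=O)(=O)N2CCOCC2)cc1)C1C(C(=O)O)[C@H]2CC[C@@H]1O2` gives 31300 nM in a functional assay on HCT-8 cells (Homo sapiens) for cytotoxicity, read by MTT assay, with a stated time of 48 h (a lower number here means a stronger inhibitor, a higher number a weaker inhibitor), and stands at one end of the three numbers shown, though compound 2 `O=C(Nc1ccc(S(=O)(=O)NC2CC2)cc1)C1C(C(=O)O)[C@H]2CC[C@@H]1O2` with 28300 nM and compound 3 `O=C(Nc1ccc(S(=O)(=O)N2CCN(c3ccc(F)cc3)CC2)cc1)C1C(C(=O)O)[C@H]2CC[C@@H]1O2` with 16600 nM both lie within the scatter of it. Among the compounds with values here, the only measured step at the sulfonyl sulfur, a 1.1-fold lower number from compound 1 to compound 2 (0.04 log units; within the scatter), puts cyclopropylamino in place of morpholin-4-yl and stays within the scatter. Compound 4 `CCN1CCN(S(=O)(=O)c2ccc(NC(=O)C3C(C(=O)O)[C@H]4CC[C@@H]3O4)cc2)CC1` differs from compound 1 by 4-ethylpiperazin-1-yl in place of morpholin-4-yl on a sulfonyl sulfur. This change sits at the same place as that step, and the value of compound 3 suggests that a larger group there moves the number little. The expected step is a 1.3-fold lower number from compound 1 to compound 4 (0.10 log units; within the scatter), nothing beyond the scatter. Compound 4 is therefore estimated at 25000 nM, with a range from 10000 nM to 60000 nM.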

Compound 4, half-maximal inhibitory concentration: 27400 nM
Beside the measured number, compound 4's estimate is 1.1-fold (0.04 log units) below it; measured number inside the range.
By their numbers in this assay, from the lowest: compounds 3, 4, 2 and 1 (each within the scatter of the next).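

Every new step at this position stays within the scatter in this assay: 4-ethylpiperazin-1-yl on a sulfonyl sulfur gives little movement against morpholin-4-yl (a 1.1-fold lower number from compound 1 to compound 4 (0.06 log units; within the scatter)) or against cyclopropylamino (a 1.0-fold lower number from compound 2 to compound 4 (0.01 log units; within the scatter)). Within the data shown here, the first step on the amine nitrogen in a ring, ethyl in place of 4-fluorophenyl (a 1.7-fold higher number from compound 3 to compound 4 (0.22 log units; within the scatter)), also stays within it. No evidence accompanies these results. As far as these compounds go, whether a plain amino group or a carboxylic acid on the sulfonyl sulfur would move the number remains open. So does the effect of a longer chain on the amine nitrogen in a ring.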